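Changing the Halogen Pattern in a Small Oxime Series

A few compounds are considered here, and "the series" means these few. Any claim that something is new, unique, unknown or untested is made for them only; others in the source may bear on it.

Compound 1, `O/N=C(\CCN1CCN(c2ccccn2)CC1)c1ccccc1Cl`, gives 74%.
Compound 2, `O/N=C(\CCN1CCN(c2ccccn2)CC1)c1cccc(Cl)c1`, gives 73%.
Compound 3, `O/N=C(\CCN1CCN(c2ccccn2)CC1)c1ccc(F)cc1`, gives 74%.

These three compounds were tested in a functional assay on HEK293 cells with D(4) dopamine receptor (Homo sapiens) as the target, read by FLIPR; on this read-out higher numbers stand for larger maximal responses and lower numbers for smaller maximal responses. Compound 3 sits level with compound 1 at the digits shown, and the two together are the highest of the three numbers, but the difference to compound 2 is small and within the scatter, so the three compounds cannot be ranked against one another.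

Compound 4, `O/N=C(\CCN1CCN(c2ccccn2)CC1)c1cc(F)cc(F)c1`, has not yet been tested. It differs from compound 3 as follows: 3,5-difluorophenyl in place of 4-fluorophenyl on a carbon with a double bond to nitrogen

Going by the values given here, every measured step so far has moved a halogen on this phenyl ring without a real effect: a number 1 percentage points lower from compound 1 to compound 2 (within the scatter), no change at the digits printed from compound 1 to compound 3 (within the scatter) and a number 1 percentage points higher from compound 2 to compound 3 (within the scatter). None of these steps is the same as adding a second fluorine, but all of them point the same way. Compound 4 is therefore expected to land at 73% in this assay, with a likely range from 63% to 83%. That corresponds to an expected step of a number 1 percentage points lower from compound 3 to compound 4 (within the scatter), which is no change beyond the scatter.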

Compound 4, largest response reached (reported as efficacy), in percent of the reference or control that the assay uses: 74%
Beside the measured number, compound 4's estimate is 1 percentage points below it; the measured number falls inside the stated range.
By their numbers in this assay, from the lowest: compounds 2, 1, 3 and 4 (each within the scatter of the next).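

A second fluorine on this phenyl ring, not just a halogen moved to another spot, also leaves the maximal response in this assay unshifted: 3,5-difluorophenyl in place of 4-fluorophenyl gives no change at the digits printed from compound 3 to compound 4 (within the scatter) on the carbon with a double bond to nitrogen. The new group also cannot be told apart from the chlorine-bearing rings, with a number 1 percentage points higher from compound 2 to compound 4 (within the scatter) and no change at the digits printed from compound 1 to compound 4 (within the scatter) as the two further steps. No supporting data here explain why the response holds steady across these rings.

All four rings shown carry only chlorine or fluorine, so it remains open whether a methoxy group, a nitrile or an amine on the ring would move the response beyond the scatter. The saturated chain is also the same throughout, which leaves the effect of a longer chain unknown.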